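This account rests on a few compounds, and the source may have more. Where it says the series, first, only, none or still open, it means among the compounds named here.

Measured so far:
compound 1 `COc1ccc2cc([C@H](C)c3nnc(SCc4ccc(C)cc4)n3-c3ccc(F)cc3)ccc2c1`: <= 400000 nM (a limit)
compound 2 `COc1ccc2cc([C@H](C)c3nnc(SCc4ccccc4)n3-c3ccc(Cl)cc3)ccc2c1`: 50400 nM

Both compounds were tested in a functional assay on LNCaP cells (Homo sapiens) for cytotoxicity, read by MTT assay (on this read-out higher numbers stand for weaker inhibition and lower numbers for stronger inhibition), and gave quite different kinds of result. Compound 1 stands at the limit of <= 400000 nM in this assay, at which 1 of the 2 values shown sits, and this is a limit, not a number. In this assay compound 2 gives a true number of 50400 nM and so offers a firmer reference point. Going by the values given here, no two measured compounds differ in one place only, so no measured step is available as a guide.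

Compound 3 `COc1ccc2cc([C@H](C)c3nnc(SCc4ccc(F)cc4)n3-c3ccc(F)cc3)ccc2c1` has not yet been measured. It keeps the core of compound 1 and carries one change: fluoro in place of methyl on an aromatic carbon, which turns 4-methylbenzyl into 4-fluorobenzyl. Among the compounds with values here, with compound 2 at 50400 nM as the only true number to lean on, a reading for compound 3 in that region is expected. A move towards lower numbers in this assay is therefore expected, and the estimated step that the limit leaves unreadable from compound 1 to compound 3 is only a rough figure. Compound 3 is expected at 70000 nM, with an estimated range from 20000 nM to 250000 nM.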

Compound 3, half-maximal inhibitory concentration: 104000 nM
For compound 3 the middle estimate is 1.5-fold (0.17 log units) below the measured one, within the range that was stated.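

No step can be read from compound 1 to compound 3 in this assay, because compound 1 gives a limit and not a number: the limit of <= 400000 nM in this assay, at which 1 of the 3 values shown sits.

The compounds shown leave open how far the change from 4-methylbenzyl to 4-fluorobenzyl moves the value, since no pair differing in that one place has true numbers on both sides.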